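Sulfonyl substituent changes in a weak series

This account rests on a few compounds, and the source may have more. Where it says the series, first, only, none or still open, it means among the compounds named here.

The compounds share one core and differ only in the group on the sulfonyl sulfur. Compound 1 `O=S(=O)(Nc1ccc2oc(-c3ccccc3)nc2c1)c1cccs1` carries thiophen-2-yl there and in an assay on cells for inhibition of HSP60/HSP10 (Homo sapiens), with a stated time of 60 min (a higher number here means a weaker inhibitor, a lower number a stronger inhibitor), gives 90000 nM. Compound 2 `COc1ccc(S(=O)(=O)Nc2ccc3oc(-c4ccccc4)nc3c2)cc1` carries 4-methoxyphenyl; in this assay compound 2 returns only > 100000 nM, which is a limit of the assay and not a number (the limit of > 100000 nM in this assay, at which 1 of the 3 values shown sits). Compound 3 `O=S(=O)(Nc1ccc2oc(-c3ccccc3)nc2c1)c1ccc(Cl)s1` carries 5-chlorothiophen-2-yl and in this assay gives 70000 nM; on the numbers shown compound 3 stands as the lower of the two, with compound 1 nearest to it and within the scatter. The measured steps are an at least 1.1-fold higher number from compound 1 to compound 2 (0.04 log units; that floor lies within the scatter), a 1.3-fold lower number from compound 1 to compound 3 (0.11 log units; within the scatter) and an at least 1.4-fold lower number from compound 2 to compound 3 (0.15 log units; that floor lies within the scatter), none of them beyond the scatter.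

Compound 4 `CS(=O)(=O)Nc1ccc2oc(-c3ccccc3)nc2c1` is not yet measured. The change from compound 3 is methyl in place of 5-chlorothiophen-2-yl on a sulfonyl sulfur. All three measured steps alter the same sulfonyl substituent, and none moved the read-out beyond the scatter, so no step beyond the scatter is expected for this change either, though a reading that ends at the limit remains possible in a series this weak. For compound 4 in this assay the estimate is 90000 nM, with a range from 40000 nM to 200000 nM. The step this estimate implies is expected to be a 1.3-fold higher number from compound 3 to compound 4 (0.11 log units; within the scatter).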

Compound 4, half-maximal inhibitory concentration: > 100000 nM
Compound 4: only a limit was reported (the forecaster's own chance of this, stated with the estimate: 45%); middle value at least 1.1-fold (0.04 log units) away from the limit.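

Compound 4, with methyl on the sulfonyl sulfur, gives > 100000 nM in this assay, which is a limit of the assay and not a number. Methyl is the only group shown here without a ring, and it leaves the series with an at least 1.4-fold higher number from compound 3 to compound 4 (0.15 log units; that floor lies within the scatter) and an at least 1.1-fold higher number from compound 1 to compound 4 (0.04 log units; that floor lies within the scatter), so replacing a thiophene-type ring with this single carbon produces no readable step beyond the scatter, and the true size of both steps stays unknown. The step between compound 2 and compound 4 cannot be read, and the position now shows a small group as well as a larger aryl group at the same limit: the limit of > 100000 nM in this assay, at which 2 of the 4 values shown sit.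

What remains open is whether any group on the sulfonyl sulfur can move the number beyond the scatter, since the compounds shown span only methyl, two thiophenes and 4-methoxyphenyl. A basic amine such as a dimethylaminoethyl chain, a carboxylic acid on the aryl ring, or a longer alkyl chain such as n-butyl would test this position in ways that these compounds do not.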